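Isonicotinoyl hydrazone series: cytotoxicity on Vero cells

The source may report more compounds than this note shows. Statements on the series, on what has been measured and on what is new or still open speak of the compounds shown alone.

Compound 1 `O=C(NN=C1CCC(c2ccccc2)CC1)c1ccncc1` and compound 2 `O=C(N/N=C/c1ccc(Oc2ccccc2)cc1)c1ccncc1` share the acyl hydrazone core and differ in the part attached to the hydrazone carbon. In an ADME assay on Vero cells (Chlorocebus sabaeus) for cytotoxicity, read by MTT assay, with a stated time of 48 h (a lower number here means a stronger inhibitor, a higher number a weaker inhibitor), compound 1 returns only a limit of the assay, > 200000 nM. For compound 2 this assay gives "not determined" (no result reported), so compound 2 stands without any number in this assay. The one result shown for the pair is that of compound 1, the limit (the limit of > 200000 nM in this assay, at which 1 of the 2 values shown sits). Compound 3 `O=Cc1ccc(/C=N/NC(=O)c2ccncc2)cc1` is not yet measured in this assay and differs from compound 2 by a single exchange, (formyl in place of phenoxy on an aromatic carbon). For the measured compounds named here, with no measured step between these two compounds, no shift beyond the usual scatter is expected in this assay in either direction, and a further limit result is the more likely outcome. For compound 3 the estimated value in this assay is 200000 nM, with an expected range from 60000 nM to 500000 nM.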

Compound 3, half-maximal inhibitory concentration in the Vero assay: > 200000 nM
Compound 3 gave a limit, no number; the forecaster's own chance of this, stated with the estimate: 70%; the middle value lies on the limit itself.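

With only a limit for compound 3 and no number for compound 2 in the Vero assay, no step can be read between them. In a physicochemical assay for lipophilicity, using the shake flask method, measured as octanol-water partition (a lower number here means a more polar compound, a higher number a more lipophilic compound), compound 2 gives 3.7 and compound 3 gives 1.32. The compounds shown leave open whether any member of the series gives a number in the Vero assay.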